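Ethylamino in place of amino on two related cores

A few compounds are considered here, and "the series" means these few. Any claim that something is new, unique, unknown or untested is made for them only; others in the source may bear on it.

In a functional assay on the whole organism with Rattus norvegicus as the target, at a dose of 40 mg/kg by the intraperitoneal route (on this read-out higher numbers stand for more inhibition at the one dose given (going by the name of the read-out) and lower numbers for less inhibition), the three measured compounds give the following numbers:
compound 1 `Cc1nc2c(CCc3ccccc3)cccn2c1N`: 47%
compound 2 `Cc1nc2c(OCc3ccccc3)nccn2c1N`: 79%
compound 3 `CCNc1c(C)nc2c(CCc3ccccc3)cccn12`: 78%

Compound 3 differs from compound 1 by one change, (ethyl in place of hydrogen on a nitrogen on an aromatic ring), and this step raised the read-out by a number 31 percentage points higher from compound 1 to compound 3 (beyond the scatter). Compound 2 carries a different core; how the two cores differ is not broken down here. Compound 4 `CCNc1c(C)nc2c(OCc3ccccc3)nccn12` is the unmeasured partner of compound 2, and it differs from compound 2 by ethyl in place of hydrogen on a nitrogen on an aromatic ring, the same change that turned compound 1 into compound 3, at the same kind of place. The numbers of compound 2 and compound 3 lie within the scatter of each other, so no order between them can be read. Going by the values given here, because compound 2 already gives 79%, the room left above it in this assay is narrow, and compound 4 is expected to move by only a number 7 percentage points higher from compound 2 to compound 4 (within the scatter), a smaller step than the one from compound 1 to compound 3. Compound 4 is therefore estimated at 86%, with a range from 72% to 96%.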

Compound 4, a percentage reported as inhibition, in the whole organism at one dose (the size of the read-out at that dose, not a potency): 48%
Estimate against measurement, compound 4: 38 percentage points above; measured number below the stated range.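

In this assay, the change from amino to ethylamino did not carry over from one core to the other: on the core of compound 2 it gave a number 31 percentage points lower from compound 2 to compound 4 (beyond the scatter), the opposite direction to the earlier step on the core of compound 1. Set side by side, the two steps differ clearly: the same change on two cores in this assay, a number 31 percentage points higher (beyond the scatter) from compound 1 to compound 3 and a number 31 percentage points lower (beyond the scatter) from compound 2 to compound 4, 62 percentage points apart, beyond the scatter of two such steps. This shows that, for these two pairs, the outcome of the change depends on the core it is made on, but it does not show which difference between the cores lies behind the reversal, and two pairs give no rule for any further core.

The compounds shown leave open whether a smaller group such as methyl, or a longer chain such as propyl, on the same nitrogen would split between the two cores in the same way. They also leave open how amino and ethylamino would compare on a core that carries only one of the differences between these two cores.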